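The source may hold more compounds than are shown below. What is called first, only, known or untested is meant among the compounds shown, and "the series" means these compounds.

Compound 1 `Cc1cc(NC(=O)Nc2ccc(C)c(Cl)c2)c2ccccc2n1` is one of three compounds tested in an ADME assay on HEK293 cells (Homo sapiens) for cytotoxicity, with a stated time of 72 h; on this read-out higher numbers stand for an effect only at larger amounts of compound and lower numbers for an effect already at smaller amounts. In this assay compound 1 gives > 25000 nM, which is a limit of the assay rather than a number. Compound 2 `COc1ccc(NC(=O)Nc2cc(C)nc3ccccc23)cc1F` also reaches only a limit, > 25000 nM. Compound 3 `Cc1cc(NC(=O)Nc2cc(F)ccc2F)c2ccccc2n1` gives a measured value of 12000 nM. Compound 1 thus stands at the limit of > 25000 nM in this assay, at which 2 of the 3 values shown sit, together with compound 2. Compound 4 `Cc1cc(NC(=O)Nc2cccc(Cl)c2)c2ccccc2n1` differs from compound 1 in one place: hydrogen in place of methyl on an aromatic carbon. Among the compounds with values here, with no measured pair showing such a change, the step from compound 1 to compound 4 in this assay is expected to stay within the usual scatter, in no particular direction, an expected step that the limit leaves unreadable from compound 1 to compound 4. Compound 4 is therefore estimated at 30000 nM, between 12000 nM and 80000 nM.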

Compound 4, half-maximal effective concentration: 21000 nM
Estimate against measurement, compound 4: 1.4-fold (0.15 log units) above; the measured number falls inside the stated range.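

Putting hydrogen in place of methyl on the aromatic carbon ortho to the chloro group gives an at least 1.1-fold lower number from compound 1 to compound 4 (0.07 log units; that floor lies within the scatter) in this assay. Within the data shown here, this is the first reading of a change at this position, and it gives only a floor, so the true step may be small or larger. That floor comes from the limit held by compound 1: the limit of > 25000 nM in this assay, at which 2 of the 4 values shown sit.

Going by these compounds, what an ethyl group, an amine or a carboxylic acid on this carbon would give in this assay stays open.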